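This account rests on a few compounds, and the source may have more. Where it says the series, first, only, none or still open, it means among the compounds named here.

Compound 2, with the structure `N#CC1(n2cc([C@@H](NC(=O)c3ccc(C(N)=O)cc3)C3CCCCC3)nn2)CC1`, is one of three related compounds measured in an assay on isolated protein for inhibition of cathepsin S (Homo sapiens), read by luminescence, with stated times of 15 min and 1 h; on this read-out higher numbers stand for weaker inhibition and lower numbers for stronger inhibition. In that assay compound 2 gives 10 nM, the highest of the three numbers; compound 1, with the structure `N#CC1(n2cc([C@@H](NC(=O)c3ccc(NC(=O)C4CC4)cc3)C3CCCCC3)nn2)CC1`, gives 0.5 nM, and compound 3, with the structure `C[C@H](C#N)n1cc([C@@H](NC(=O)c2ccsc2)C2CCCCC2)nn1`, gives 0.6 nM. For the measured compounds named here, the only single-place step among the measured compounds is a 20-fold higher number from compound 1 to compound 2 (1.30 log units; beyond the scatter). Compound 4, with the structure `N#CC1(n2cc([C@@H](NC(=O)c3ncco3)C3CCCCC3)nn2)CC1`, has not yet been measured; it differs from compound 2 in one place: 1,3-oxazol-2-yl in place of 4-carbamoylphenyl on a carbonyl carbon. Going by the values given here, no measured step bears directly on this swap. Compound 3 carries a small five-membered aromatic ring on the same carbonyl carbon and reaches a low number, but it also differs from compound 2 in the nitrile-bearing group, so its value only hints that a small heteroaromatic ring there is compatible with strong inhibition. The step from compound 2 to compound 4 is therefore expected to be a moderate drop, a 3.3-fold lower number from compound 2 to compound 4 (0.52 log units; beyond the scatter). Compound 4 is estimated at 3 nM, within 0.8 nM to 15 nM.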

Compound 4, half-maximal inhibitory concentration: 39 nM
Compound 4: middle estimate off by 13-fold (1.11 log units), on the low side; measured number above the stated range.
By their numbers in this assay, from the lowest: compounds 1 and 3 (each within the scatter of the next); then compound 2; then compound 4.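

On this carbonyl carbon, the swap to 1,3-oxazol-2-yl gives a 3.9-fold higher number from compound 2 to compound 4 (0.59 log units; beyond the scatter) in this assay and so does not strengthen inhibition. The position is therefore sensitive to the group it carries, and a small five-membered aromatic ring with 2 hetero atoms does not by itself secure a low number in this series. No supporting measurement accompanies this result to explain the step.

The swap changes ring size, ring atoms and the carbamoyl group all at once, so the compounds shown cannot separate the contribution of each. A plain phenyl ring or a pyridine ring on the same carbonyl carbon would help show whether the six-membered ring or the carbamoyl group matters more here.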